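Trading a methylsulfonyl for a trifluoromethyl ketone

The source may hold more compounds than are shown below. What is called first, only, known or untested is meant among the compounds shown, and "the series" means these compounds.

Of the compounds shown here, three have been measured in an assay on isolated protein for displacement of a labelled ligand from Bcl2-associated agonist of cell death (Homo sapiens), read by fluorescence polarization; a higher number here means a weaker inhibitor, a lower number a stronger inhibitor.
Compound 1 `CN(C)CC[C@H](CSc1ccccc1)Nc1ccc(S(=O)(=O)NC(=O)c2ccc(N3CCN(Cc4ccccc4-c4ccc(Cl)cc4)CC3)cc2)cc1` gives 14 nM.
Compound 2 `CN(C)CC[C@H](CSc1ccccc1)Nc1ccc(S(=O)(=O)NC(=O)c2ccc(N3CCN(Cc4ccccc4-c4ccc(Cl)cc4)CC3)cc2)cc1OC(F)(F)F` gives < 1 nM, which is a limit of the assay and not a number.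
Compound 3 `CN(C)CC[C@H](CSc1ccccc1)Nc1ccc(S(=O)(=O)NC(=O)c2ccc(N3CCN(Cc4ccccc4-c4ccc(Cl)cc4)CC3)cc2)cc1S(C)(=O)=O` gives < 1 nM, again a limit of the assay rather than a number.

Compound 3 thus sits at the limit of < 1 nM in this assay, at which 2 of the 3 values shown sit, so only an upper bound is known for it. The measured steps show that adding a substituent on this aromatic carbon matters: an at least 14-fold lower number from compound 1 to compound 2 (1.14 log units; beyond the scatter) and an at least 14-fold lower number from compound 1 to compound 3 (1.14 log units; beyond the scatter). The comparison between the two substituted compounds, however, is a step that the two limits leave unreadable from compound 2 to compound 3. Compound 4 `CN(C)CC[C@H](CSc1ccccc1)Nc1ccc(S(=O)(=O)NC(=O)c2ccc(N3CCN(Cc4ccccc4-c4ccc(Cl)cc4)CC3)cc2)cc1C(=O)C(F)(F)F` carries the change ((trifluoromethyl)carbonyl in place of methylsulfonyl on an aromatic carbon). For the measured compounds named here, no measured step directly addresses one substituent replacing another at this position; both substituents tried so far gave large gains over hydrogen. Compound 4 is therefore expected to remain near the limit, with a number no lower from compound 3 to compound 4 (the limit leaves the size open) expected to be no step beyond the scatter. The estimate for compound 4 is 1 nM, within a range from 0.3 nM to 5 nM.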

Compound 4, inhibition constant: < 1 nM
Compound 4 was reported as a limit (the forecaster's own chance of this, stated with the estimate: 50%); the middle value lies on the limit itself.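

In this assay compound 4 gives < 1 nM, which is a limit of the assay and not a number. The (trifluoromethyl)carbonyl is a third group on this aromatic carbon to give a large step away from hydrogen, with an at least 14-fold lower number from compound 1 to compound 4 (1.14 log units; beyond the scatter), so the gain seen earlier is not confined to trifluoromethoxy and methylsulfonyl. The steps among compound 2, compound 3 and compound 4 cannot be read, so no order among these three groups can be given: the limit of < 1 nM in this assay, at which 3 of the 4 values shown sit.

Going by these compounds, whether a nitrile, an amine or a carboxylic acid on this aromatic carbon would give a step of the same size remains open. Also open, on these data alone, is how far apart compound 2, compound 3 and compound 4 lie, which would take an assay able to give numbers for them rather than limits.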